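A methyl on the piperidine ring: the step from compound 1

The compounds below may be only part of what the source reports. "The series", "measured", "known", "first", "only" and "open" are said of these compounds alone.

Measured compounds:
- compound 1 `COc1cc2c(Oc3ccc(NC(=O)c4cn(-c5ccccc5C)nn4)cc3F)ccnc2cc1OCCCN1CCCCC1` gives 2100 nM
- compound 2 `COc1cc2c(Oc3ccc(NC(=O)c4cn(-c5ccc(Br)cc5)nn4)cc3F)ccnc2cc1OCCCN1CCCCC1` gives 360 nM
- compound 3 `COc1cc2c(Oc3ccc(NC(=O)c4cn(-c5c(C)cccc5C)nn4)cc3F)ccnc2cc1OCCCN1CCCCC1` gives 3520 nM

These three compounds were compared in a functional assay on NCI-H460 cells (Homo sapiens) for cytotoxicity, read by MTT assay, with a stated time of 72 h; on this read-out lower numbers stand for stronger inhibition and higher numbers for weaker inhibition. Compound 1 stands second highest of the three numbers, with compound 3 nearest and compound 2 furthest away. The measured steps all concern the aryl group on the triazole nitrogen: a 5.8-fold lower number from compound 1 to compound 2 (0.77 log units; beyond the scatter), a 1.7-fold higher number from compound 1 to compound 3 (0.22 log units; within the scatter) and a 9.8-fold higher number from compound 2 to compound 3 (0.99 log units; beyond the scatter).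

Compound 4 `COc1cc2c(Oc3ccc(NC(=O)c4cn(-c5ccccc5C)nn4)cc3F)ccnc2cc1OCCCN1CCC(C)CC1` differs from compound 1 in another part of the molecule: methyl in place of hydrogen on a saturated ring carbon, that is, piperidin-1-yl becomes 4-methylpiperidin-1-yl. None of the measured steps touches this ring, so no direct precedent exists among these compounds; the aryl group on the triazole nitrogen, where the measured steps were made, is the same in compound 1 and compound 4. A small added group on the saturated ring is therefore expected to leave the number about where compound 1 stands, with no step beyond the scatter in this assay, expressed as a 1.1-fold lower number from compound 1 to compound 4 (0.02 log units; within the scatter). Compound 4 is estimated at 2000 nM, with a range from 900 nM to 4500 nM.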

Compound 4, half-maximal inhibitory concentration: 2730 nM
Compound 4: middle estimate off by 1.4-fold (0.14 log units), on the low side, within the range that was stated.
By their numbers in this assay, from the lowest: compound 2; then compounds 1, 4 and 3 (each within the scatter of the next).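

The piperidine ring offers the first reading away from the aryl group on the triazole nitrogen: in this assay, adding a methyl to a saturated ring carbon, three ring bonds from the ring nitrogen, gives a 1.3-fold higher number from compound 1 to compound 4 (0.11 log units; within the scatter) and so stays within the usual scatter. This position therefore accepts a methyl on this read-out, at least with 2-methylphenyl on the triazole nitrogen, whereas changing that aryl group can give a step beyond the scatter, as with a 5.8-fold lower number from compound 1 to compound 2 (0.77 log units; beyond the scatter) for 4-bromophenyl. Nothing available here gives a reason for this reading of the methyl change.

Going by these compounds, a single methyl says little about what the ring carbon accepts in general, so it remains open whether a hydroxyl, an amine or a longer chain such as propyl at the same place would also stay within the scatter. It also remains open whether 4-methylpiperidin-1-yl would read the same when combined with the 4-bromophenyl group of compound 2, whose number is the lowest of those shown.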